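The source may hold more compounds than are shown below. What is called first, only, known or untested is meant among the compounds shown, and "the series" means these compounds.

In a functional assay on L1210 cells (Mus musculus) for inhibition (on this read-out higher numbers stand for weaker inhibition and lower numbers for stronger inhibition), compound 2 `Nc1nc(O)c2ncn(C/C=C\CO)c2n1` gives 680000 nM, the highest of the three numbers, which makes it the weakest inhibitor measured so far. Compound 1 `Nc1nc(O)c2ncn(C/C=C/CO)c2n1` gives 200000 nM, and compound 3 `Nc1ncnc2c1ncn2C=C=CCCl` gives 45000 nM. Compound 4 `Nc1nc(O)c2ncn(C=C=CCO)c2n1` has 4-hydroxybuta-1,2-dien-1-yl in place of 4-hydroxybut-2-en-1-yl on an aromatic nitrogen. Within the data shown here, only one measured step bears on this chain, a 3.4-fold higher number from compound 1 to compound 2 (0.53 log units; beyond the scatter), and it is modest and goes with the fact that compounds 1 and 2 differ only in the configuration as drawn. A step of similar modest size is therefore expected in this assay, toward a lower number, with compound 2 at the top of the three. The expected change is a 3.4-fold lower number from compound 2 to compound 4 (0.53 log units; beyond the scatter). For compound 4 the estimate is 200000 nM, with an expected range of 50000 nM to 700000 nM.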

Compound 4, half-maximal inhibitory concentration: > 350000 nM
Compound 4 gave a limit, no number; the forecaster's own chance of this, stated with the estimate: 25%; middle value at least 1.7-fold (0.24 log units) from the limit.
By their numbers in this assay, from the lowest: compound 3; then compound 1; then compound 2.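

In this assay compound 4 gives > 350000 nM, which is a limit of the assay and not a number. Against the 4-hydroxybut-2-en-1-yl chain of compound 1, the 4-hydroxybuta-1,2-dien-1-yl chain on the aromatic nitrogen gives an at least 1.7-fold higher number from compound 1 to compound 4 (0.24 log units; that floor lies within the scatter), so this change brings no gain in inhibition, though the floor of that step does not firmly separate the two compounds. The step from compound 2 cannot be read. On these data alone, the actual number for compound 4 stays open. Also open, as far as these compounds go, is whether an amine in place of the hydroxyl, or a longer chain, would change the inhibition.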